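Moving the ring nitrogen on the amide-type nitrogen of compound 3

A few compounds are considered here, and "the series" means these few. Any claim that something is new, unique, unknown or untested is made for them only; others in the source may bear on it.

Of the compounds shown here, three sharing one core have been measured in an assay on HEK293 cells for agonist activity at transient receptor potential cation channel subfamily M member 8 (Homo sapiens), read by fluorescence and calcium flux, with a stated time of 15 min; on this read-out lower numbers stand for an effect already at smaller amounts and higher numbers for an effect only at larger amounts of compound. Compound 1 `Cc1ccc(OCC(=O)N(CCCO)Cc2cccs2)cc1` carries a 3-hydroxypropyl group on its amide-type nitrogen and gives 3000 nM. Compound 2 `Cc1ccc(OCC(=O)N(Cc2cccs2)c2ccn[nH]2)cc1` carries 1H-pyrazol-5-yl there and gives 0.2 nM. Compound 3 `Cc1ccc(OCC(=O)N(Cc2cccs2)c2ccncc2)cc1` carries pyridin-4-yl and gives 52 nM, which places it second highest of the three numbers: the step of a 58-fold lower number from compound 1 to compound 3 (1.76 log units; beyond the scatter) is large, and the step of a 260-fold higher number from compound 2 to compound 3 (2.41 log units; beyond the scatter) is large in the other direction, so compound 3 sits far from both neighbours.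

Compound 4 `Cc1ccc(OCC(=O)N(Cc2cccs2)c2ccccn2)cc1` differs from compound 3 by a single change, (pyridin-2-yl in place of pyridin-4-yl on an amide-type nitrogen). Going by the values given here, no measured step swaps one pyridinyl for another, so the relevant comparisons are indirect: the step of a 15000-fold lower number from compound 1 to compound 2 (4.18 log units; beyond the scatter) and the step of a 260-fold higher number from compound 2 to compound 3 (2.41 log units; beyond the scatter) show that small aromatic rings on this amide-type nitrogen can differ from one another by a very large margin in this assay, whereas both aromatic rings beat the 3-hydroxypropyl chain of compound 1. Among the compounds with values here, with no direct precedent, the size of the change cannot be anchored, but the aromatic rings measured so far range widely, and compound 4 is expected to fall between compound 2 and compound 3, a step of a 6.5-fold lower number from compound 3 to compound 4 (0.81 log units; beyond the scatter). Compound 4 is therefore estimated at 8 nM, with a range from 0.8 nM to 60 nM.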

Compound 4, half-maximal effective concentration: 200 nM
The estimate for compound 4 lay 25-fold (1.40 log units) below the measured number; measured number outside the range, above it.
By their numbers in this assay, from the lowest: compound 2; then compound 3; then compound 4; then compound 1.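

Moving the ring nitrogen alone is enough to register in this assay, since the two groups have the same atoms and the same counts, yet pyridin-2-yl in place of pyridin-4-yl on the amide-type nitrogen gives a modest step beyond the scatter (a 3.8-fold higher number from compound 3 to compound 4 (0.59 log units; beyond the scatter)). The new ring still holds a large advantage over the 3-hydroxypropyl chain (a 15-fold lower number from compound 1 to compound 4 (1.18 log units; beyond the scatter)) but stays much further from the 1H-pyrazol-5-yl ring (a 1000-fold higher number from compound 2 to compound 4 (3.00 log units; beyond the scatter)), so at this position the choice of ring weighs far more than where the nitrogen sits within the pyridine ring, and neither pyridinyl group comes close to compound 2. No supporting evidence accompanies these numbers, so what lies behind the differences stays unexplained.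

The compounds shown leave open where pyridin-3-yl or a plain phenyl ring would fall on this amide-type nitrogen, which would show whether the ring nitrogen matters at every placement. They also leave open whether another five-membered ring, such as imidazol-2-yl, or a methyl group added to the 1H-pyrazol-5-yl ring would keep a number near that of compound 2.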